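The source may report more compounds than this note shows. Statements on the series, on what has been measured and on what is new or still open speak of the compounds shown alone.

Measured compounds:
Compound 1, `Cc1nc2cc(C(=O)NCc3ccc(F)cc3)nn2c(-c2cc(F)c3c(c2C)CCCO3)c1[C@H](OC(C)(C)C)C(=O)O`: in an ADME assay on MT2 cells (Homo sapiens) for cytotoxicity (on this read-out higher numbers stand for lower toxicity in this test and lower numbers for higher toxicity in this test), compound 1 gives > 40000 nM, which is a limit of the assay rather than a number.
Compound 2, `COc1cc(F)ccc1CNC(=O)c1cc2nc(C)c([C@H](OC(C)(C)C)C(=O)O)c(-c3cc(F)c4c(c3C)CCCO4)n2n1`: in this assay compound 2 gives > 40000 nM, again a limit of the assay.
Compound 3, `CNC(=O)c1cc(F)ccc1CNC(=O)c1cc2nc(C)c([C@H](OC(C)(C)C)C(=O)O)c(-c3cc(F)c4c(c3C)CCCO4)n2n1`: in this assay compound 3 gives > 40000 nM, also a limit of the assay.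

Compound 3 therefore stands where every compound here stands, at the limit of > 40000 nM in this assay, at which 3 of the 3 values shown sit, and no ordering among the three can be read. The steps a step that the two limits leave unreadable from compound 1 to compound 2, a step that the two limits leave unreadable from compound 1 to compound 3 and a step that the two limits leave unreadable from compound 2 to compound 3 are all unreadable, since each runs from one limit to another.

Compound 4, `Cc1nc2cc(C(=O)NCCC3CCCCC3)nn2c(-c2cc(F)c3c(c2C)CCCO3)c1[C@H](OC(C)(C)C)C(=O)O`, has not yet been measured. It differs from compound 3 by cyclohexylmethyl in place of 4-fluoro-2-(methylcarbamoyl)phenyl on a saturated chain carbon bound to an amide-type nitrogen. For the measured compounds named here, none of the measured steps concern this part of the molecule; all of them exchange a group on an aromatic carbon of the ring that now leaves, so no measured step bears directly on the change. Going by the values given here, with every value so far at the limit, the expectation for compound 4 is a step of a number no higher from compound 3 to compound 4 (the limit leaves the size open), that is, none readable beyond the scatter. Compound 4 is thus estimated at 40000 nM, within a range from 15000 nM to 100000 nM, and most likely the assay will again report only a limit.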

Compound 4, half-maximal cytotoxic concentration: > 40000 nM
Compound 4: only a limit was reported (the forecaster's own chance of this, stated with the estimate: 75%); the middle value lies on the limit itself.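

In this assay compound 4 gives > 40000 nM, again a limit of the assay. Its steps from compound 1, compound 2 and compound 3 cannot be read, each running from one limit to another: the limit of > 40000 nM in this assay, at which 4 of the 4 values shown sit.

The compounds shown leave open at what concentration any of them would become cytotoxic, and whether the amide side groups differ in this respect.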